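Compound 4: the R form against the undefined compound 2

The source may hold more compounds than are shown below. What is called first, only, known or untested is meant among the compounds shown, and "the series" means these compounds.

Values in an ADME assay on Huh-7 cells (Homo sapiens) for cytotoxicity (on this read-out higher numbers stand for lower toxicity in this test and lower numbers for higher toxicity in this test), so far
compound 1 `CC(C)CC[C@@]1(C)C(=O)C(C2=NS(=O)(=O)c3cc(NS(C)(=O)=O)ccc3N2)=C(O)c2cccn21` gives 19500 nM
compound 2 `CC(C)CCC1(C)C(=O)C(C2=NS(=O)(=O)c3cc(NS(C)(=O)=O)ccc3N2)=C(O)c2cccn21` gives > 100000 nM (a limit)
compound 3 `CC(C)CCC1(C)C(=O)C(C2=NS(=O)(=O)c3cc(NS(C)(=O)=O)ccc3N2)=C(O)c2cncn21` gives > 100000 nM (a limit)

Compound 2 stands at the limit of > 100000 nM in this assay, at which 2 of the 3 values shown sit, and so has no exact number. Compound 4 `CC(C)CC[C@]1(C)C(=O)C(C2=NS(=O)(=O)c3cc(NS(C)(=O)=O)ccc3N2)=C(O)c2cccn21` carries the two compounds have the same atoms and bonds; at least one stereo element is drawn with a configuration in one of them and without one in the other: 1 of 1 stereo elements differ; a stereocentre at a saturated ring carbon is drawn without a configuration in compound 2 and R in compound 4 and keeps the same atoms and bonds. Within the data shown here, the one measured step at this stereocentre is an at least 5.1-fold higher number from compound 1 to compound 2 (0.70 log units; beyond the scatter) and it goes with the fact that one of compounds 1 and 2 is drawn with a defined configuration and the other without, at the place where they differ as the only structural difference. Compound 4 is drawn R where compound 1, at 19500 nM, is drawn S, so the lower number of that S form is not expected to carry over. Expected in this assay is a number no higher from compound 2 to compound 4 (the limit leaves the size open) and no step beyond the scatter. Compound 4 is estimated at 100000 nM with a range from 30000 nM to 200000 nM and is expected that it may turn out as a limit again.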

Compound 4, half-maximal cytotoxic concentration: 170000 nM
Estimate against measurement, compound 4: 1.7-fold (0.23 log units) below; the range from low to high includes it.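

In this assay, the two defined forms can now be compared directly, giving an 8.7-fold higher number from compound 1 to compound 4 (0.94 log units; beyond the scatter). The lower number therefore belongs to the S form of compound 1, with configuration as the only difference: the fact that compounds 1 and 4 differ only in the configuration as drawn

The step from compound 2 to compound 4 cannot be read, as compound 2 has only a limit.

Still open, on these data alone, is whether this gap between the S and R forms persists with a longer chain, or with an amine or a carboxylic acid on the chain, at this stereocentre.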